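A few compounds are considered here, and "the series" means these few. Any claim that something is new, unique, unknown or untested is made for them only; others in the source may bear on it.

Compound 1: `Cc1ccc(-c2c3c(nc(C)c2C(OC(C)(C)C)C(=O)O)CCN(Cc2ccccc2-c2ccccc2)C3)cc1` — > 40000 nM
Compound 2: `Cc1nc2c(c(-c3cc(F)c4c(c3C)CCCO4)c1[C@H](OC(C)(C)C)C(=O)O)CN(CCCc1ccc(F)cc1)CC2` — > 40000 nM

Both values in an ADME assay on MT2 cells (Homo sapiens) for cytotoxicity, read by XTT assay, with a stated time of 4 days (a lower number here means that less compound is tolerated, a higher number that more compound is tolerated), are limits of the assay rather than numbers. Compound 2 gives > 40000 nM, a limit; compound 1 gives > 40000 nM, also a limit, so compound 2 stands at the limit of > 40000 nM in this assay, at which 2 of the 2 values shown sit. Compound 3 is `Cc1nc2c(c(-c3cc(F)c4c(c3C)CCCO4)c1[C@H](OC(C)(C)C)C(=O)O)CN(CCCc1ccncc1)CC2`, not yet measured in this assay. Its change from compound 2 is pyridin-4-yl in place of 4-fluorophenyl on a saturated chain carbon, three bonds along the chain from an amine nitrogen in a ring. For the measured compounds named here, with no measured step to guide it, I expect no change beyond the scatter, and the step of a number no higher from compound 2 to compound 3 (the limit leaves the size open) is estimated as none. Compound 3 is expected to give about 40000 nM, within 20000 nM to 80000 nM, most likely again as a limit.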

Compound 3, half-maximal cytotoxic concentration: > 40000 nM
Compound 3: only a limit was reported (the forecaster's own chance of this, stated with the estimate: 80%); the middle value lies on the limit itself.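

No step can be read from compound 2 to compound 3, since both results are limits and not numbers: the limit of > 40000 nM in this assay, at which 3 of the 3 values shown sit. The compounds shown leave open whether pyridin-4-yl in place of 4-fluorophenyl changes how much compound the cells tolerate.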